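Working notes: from compound 2 to compound 3

The source may hold more compounds than are shown below. What is called first, only, known or untested is meant among the compounds shown, and "the series" means these compounds.

Measured in a functional assay on RCC4 cells (Homo sapiens) for inhibition, read by XTT assay, with a stated time of 4 days; on this read-out higher numbers stand for weaker inhibition and lower numbers for stronger inhibition:
- compound 1 `Cc1cccc(Nc2nc(-c3ccnc(-c4ccncc4)c3)cs2)c1`: 28900 nM; 29500 nM (2 entries)
- compound 2 `Cc1cccc(Nc2nc(-c3ccnc(CCCO)c3)cs2)c1`: 5250 nM

Compound 2 has a single number, 5250 nM, which is lower, and so stronger, than the entries for compound 1 at 28900 nM; 29500 nM (2 entries). Compound 3 `Cc1cccc(Nc2nc(-c3ccnc(C)c3)cs2)c1` has not yet been measured. It carries hydrogen in place of 2-hydroxyethyl on a saturated chain carbon bound to an aromatic carbon, which reads as 3-hydroxypropyl to methyl. Among the compounds with values here, no measured pair shows this change, so the expectation rests on compound 2 at 5250 nM alone. In this assay, no change beyond the scatter is expected, in either direction, and the expected step of a 1.1-fold lower number from compound 2 to compound 3 (0.02 log units; within the scatter) carries wide uncertainty. For compound 3 the estimate is 5000 nM, with an expected range of 1500 nM to 20000 nM.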

Compound 3, half-maximal inhibitory concentration: 28800 nM
For compound 3 the middle estimate is 5.8-fold (0.76 log units) below the measured one; measured number outside the range, above it.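

In this assay, the change from 3-hydroxypropyl to methyl gives a 5.5-fold higher number from compound 2 to compound 3 (0.74 log units; beyond the scatter), so this position responds to what it carries, and the lower number of compound 2 goes with its 3-hydroxypropyl chain. Removing the 2-hydroxyethyl leaves compound 3 at 28800 nM, a number that lies with those of compound 1, even though compound 1 and compound 3 carry different groups at this position. The level is not a one-off reading for the series, as the repeat entries of compound 1 agree closely: the several entries of compound 1 in this assay, 28900 nM; 29500 nM (2 entries)

The compounds shown leave open whether the lower number of compound 2 goes with the hydroxyl or with the chain alone, which a plain propyl chain would separate. On these data alone, how a 3-aminopropyl group, a carboxylic acid or a longer hydroxyalkyl chain would read at this position also remains open.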